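Extending the Chain of Compound 2 Toward a Phenoxy Group

The source may hold more compounds than are shown below. What is called first, only, known or untested is meant among the compounds shown, and "the series" means these compounds.

The measurements come from a functional assay on MSTO-211H cells (Homo sapiens) for inhibition, read by trypan blue exclusion, with a stated time of 72 h; a lower number here means a stronger inhibitor of growth, a higher number a weaker inhibitor of growth. Compound 1 `CCCn1c(-c2ccc(O)cc2)c(C)c2cc(O)ccc21` gives 2900 nM in this assay. Compound 2 `CCCn1c(-c2ccc(O)c(O)c2)c(C)c2cc(O)ccc21`, by contrast, reaches only the limit of this assay, reported as > 20000 nM. Compound 3 `Cc1ncsc1C(=O)Oc1ccc(-c2[nH]c3ccccc3c2C)cc1` likewise returns only the limit of this assay, > 20000 nM. Among the compounds with values here, the one step that can be read between these compounds is an at least 6.8-fold higher number from compound 1 to compound 2 (0.83 log units; beyond the scatter), a change of hydroxy in place of hydrogen on an aromatic carbon, and because the limit of > 20000 nM in this assay, at which 2 of the 3 values shown sit, the true size of that step cannot be pinned down; compound 2 therefore stands at the weak end of what this assay can report.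

Compound 4 `Cc1c(-c2ccc(O)c(O)c2)n(CCCOc2ccccc2)c2ccc(O)cc12` carries the change (phenoxy in place of hydrogen on a saturated chain carbon, three bonds along the chain from an aromatic nitrogen). Within the data shown here, no measured step concerns a group added on this saturated chain; the single known step involves an aromatic carbon instead. Among the measured compounds shown here, with no comparable step to lean on, and with compound 2 already sitting at the limit, compound 4 is expected to remain at or near that limit. The step of a number no higher from compound 2 to compound 4 (the limit leaves the size open) is the estimated outcome. Compound 4 is expected to give about 20000 nM in this assay, within a range from 7000 nM to 60000 nM.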

Compound 4, concentration for 50% growth inhibition: 7100 nM
For compound 4 the middle estimate is 2.8-fold (0.45 log units) above the measured one, and the stated range covers the measured number.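

In this assay, within the data shown here, the earlier compounds offered only one readable step, on an aromatic carbon, and it went toward weaker growth inhibition; the saturated chain now gives a step in the other direction, with phenoxy in place of hydrogen on a saturated chain carbon, three bonds along the chain from an aromatic nitrogen, producing an at least 2.8-fold lower number from compound 2 to compound 4 (0.44 log units; beyond the scatter). This shows that the chain position tolerates a much larger group, one that brings a six-membered aromatic ring of carbon only, and that growth inhibition can be read as a number again on a core that also carries the added hydroxy. Compound 2 gives > 20000 nM, which is a limit and not a number, and the full size of the step stays unknown because one end of it rests on that limit: the limit of > 20000 nM in this assay, at which 2 of the 4 values shown sit.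

The compounds shown do not separate the part played by the aromatic ring from that of the oxygen or the added length, which a longer chain, an amine or a carboxylic acid at the same place could help to tell apart. Going by these compounds, whether phenoxy would shift the number in the same direction on the core of compound 1 also remains open.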